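Thiophene in Place of Methoxyphenyl in an Endothelin Series

The compounds below may be only part of what the source reports. "The series", "measured", "known", "first", "only" and "open" are said of these compounds alone.

Compound 1, `CSc1cnc(OCCOc2ncnc(NS(=O)(=O)c3ccc(C(C)(C)C)cc3)c2-c2ccc(Cl)cc2)nc1`: < 0.001 nM
Compound 2, `CSc1cnc(OCCOc2ncnc(NS(=O)(=O)c3ccc(C(C)(C)C)cc3)c2-c2ccc(C(F)(F)F)cc2)nc1`: 0.0017 nM
Compound 3, `COc1ccc(-c2c(NS(=O)(=O)c3ccc(C(C)(C)C)cc3)ncnc2OCCOc2ncc(SC)cn2)cc1`: < 0.001 nM

Of the compounds shown here, three sharing one core have been measured in an assay on cells (Endothelial cell) for binding affinity to Endothelin-1 receptor (Sus scrofa); on this read-out lower numbers stand for stronger inhibition and higher numbers for weaker inhibition. Compound 1 gives < 0.001 nM, which is a limit of the assay rather than a number. Compound 2 gives 0.0017 nM. Compound 3 also sits at a limit, < 0.001 nM, so its standing among the three cannot be placed more exactly than at the strongest end the read-out can report; that two of the three values rest on this floor the limit of < 0.001 nM in this assay, at which 2 of the 3 values shown sit, shows how little room is left to resolve differences.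

Compound 4, `CSc1cnc(OCCOc2ncnc(NS(=O)(=O)c3ccc(C(C)(C)C)cc3)c2-c2cccs2)nc1`, is not yet measured. It differs from compound 3 in one place: thiophen-2-yl in place of 4-methoxyphenyl on an aromatic carbon. The measured steps all exchange the group on the six-membered ring of carbon only rather than the ring itself: an at least 1.7-fold higher number from compound 1 to compound 2 (0.23 log units; that floor lies within the scatter), a step that the two limits leave unreadable from compound 1 to compound 3, and an at least 1.7-fold lower number from compound 2 to compound 3 (0.23 log units; that floor lies within the scatter). None of them shows a step clearly beyond the scatter, and none tests a change of ring, so they bear on the new step only loosely.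

Compound 4 is therefore estimated at 0.002 nM, with a range from 0.0005 nM to 0.01 nM. This amounts to an expected step of an at least 2.0-fold higher number from compound 3 to compound 4 (0.30 log units; that floor lies within the scatter), and another limit is a real possibility.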

Compound 4, half-maximal inhibitory concentration: 0.89 nM
Compound 4: middle estimate off by 450-fold (2.65 log units), on the low side, and the stated range ends below it.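

The earlier compounds shown here changed only the group carried on the six-membered ring of carbon, and in this assay none of those steps lay clearly beyond the scatter; exchanging the ring itself at this position behaves very differently. Thiophen-2-yl in place of 4-methoxyphenyl gives an at least 890-fold higher number from compound 3 to compound 4 (2.94 log units; beyond the scatter), in place of 4-(trifluoromethyl)phenyl it gives a 520-fold higher number from compound 2 to compound 4 (2.72 log units; beyond the scatter), and in place of 4-chlorophenyl it gives an at least 890-fold higher number from compound 1 to compound 4 (2.94 log units; beyond the scatter), so in all three comparisons the read-out responds strongly to which ring sits on this aromatic carbon. Among these compounds, only the step from compound 2 has a definite size, because the other two rest on a limit: the limit of < 0.001 nM in this assay, at which 2 of the 4 values shown sit.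

In compound 4 two things change together, the ring becomes five-membered with a sulfur in it and the group on the six-membered ring is gone, and a plain phenyl group or a thiophene bearing a chloro group would help tell these two apart. From the compounds shown here alone, it also stays open whether this step belongs to thiophen-2-yl alone or extends to other five-membered rings, such as thiophen-3-yl or furan-2-yl.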